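Swapping Cyclopropylmethyl for a Hydroxymethyl-Bearing Branch

The source may hold more compounds than are shown below. What is called first, only, known or untested is meant among the compounds shown, and "the series" means these compounds.

Measured compounds:
Compound 1, `C[C@@H](NC(=O)c1ccc(C#Cc2cccc(F)c2)cn1)C(C)(C)C`, gives 66% in a functional assay on HEK293 cells for positive allosteric modulation of metabotropic glutamate receptor 5 (Rattus norvegicus), read by fluorescence and calcium flux; on this read-out lower numbers stand for smaller maximal responses and higher numbers for larger maximal responses.
Compound 2, `CC(C)[C@H](C)NC(=O)c1ccc(C#Cc2cccc(F)c2)cn1`, gives 66.7% in this assay.
Compound 3, `O=C(NCC1CC1)c1ccc(C#Cc2cccc(F)c2)cn1`, gives 61.4% in this assay.

All three share one core and differ only in the group on the amide-type nitrogen. Compound 3 sits alongside the other two: the steps of a number 4.6 percentage points lower from compound 1 to compound 3 (within the scatter) and a number 5.3 percentage points lower from compound 2 to compound 3 (within the scatter) are both within the scatter, as is a number 0.7 percentage points higher from compound 1 to compound 2 (within the scatter), so none of the three can be set apart on these numbers.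

Compound 4, `CC(C)(CO)NC(=O)c1ccc(C#Cc2cccc(F)c2)cn1`, has not yet been measured. It differs from compound 3 in one place: 1-(hydroxymethyl)-1-methylethyl in place of cyclopropylmethyl on an amide-type nitrogen. The measured steps that bear on this position are a number 4.6 percentage points lower from compound 1 to compound 3 (within the scatter) and a number 5.3 percentage points lower from compound 2 to compound 3 (within the scatter), and each stayed within the scatter. Among the measured compounds shown here, the data hold no step that brings in a hydrogen-bond donor, so that part of the change is untested. On this basis the expected step is a number 1.6 percentage points higher from compound 3 to compound 4 (within the scatter), within the scatter. Compound 4 is estimated at 63%, with a range from 48% to 78%.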

Compound 4, largest response reached (reported as efficacy), in percent of the reference or control that the assay uses: 60.9%
Beside the measured number, compound 4's estimate is 2.1 percentage points above it, and the stated range covers the measured number.
By their numbers in this assay, from the lowest: compounds 4, 3, 1 and 2 (each within the scatter of the next).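

On the amide-type nitrogen, 1-(hydroxymethyl)-1-methylethyl brings in a hydrogen-bond donor and has no ring, yet in this assay the change from cyclopropylmethyl is a number 0.5 percentage points lower from compound 3 to compound 4 (within the scatter) and so gives the first sign that a donor at this position leaves the maximal response within the scatter. The same holds against the two larger carbon-only groups, with a number 5.8 percentage points lower from compound 2 to compound 4 (within the scatter) and a number 5.1 percentage points lower from compound 1 to compound 4 (within the scatter) as the steps. No measurement here offers an explanation for this result.

All four groups on this nitrogen carry no net charge, so an amine or a carboxylic acid there remains an open question. Also open, going by these compounds, is whether a tert-butyl group, the same branch without its hydroxyl, or a longer chain ending in hydroxyl would read alike.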